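The source may report more compounds than this note shows. Statements on the series, on what has been measured and on what is new or still open speak of the compounds shown alone.

Measured in a functional assay on SMMC-7721 cells (Homo sapiens) for inhibition, read by CCK-8 assay, with a stated time of 72 h; a lower number here means a stronger inhibitor, a higher number a weaker inhibitor:
- compound 1 `Nc1ccccc1NC(=O)c1ccc(CNC(=O)c2n[nH]cc2NC(=O)c2c(F)cccc2Cl)cc1`: 16300 nM
- compound 2 `Nc1ccccc1NC(=O)c1ccc(CNC(=O)c2n[nH]cc2NC(=O)c2ccccc2Cl)cc1`: 12900 nM
- compound 3 `COc1ccccc1C(=O)Nc1c[nH]nc1C(=O)NCc1ccc(C(=O)Nc2ccccc2N)cc1`: 8320 nM

Compound 3, at 8320 nM, stands within the scatter of both other compounds, so no order among the three can be claimed. The next compound, compound 4 `Nc1ccccc1NC(=O)c1ccc(CNC(=O)c2n[nH]cc2NC(=O)c2c(F)cccc2F)cc1`, is still to be measured. It carries 2,6-difluorophenyl in place of 2-methoxyphenyl on a carbonyl carbon.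

Among the measured compounds shown here, the closest precedent is a 2.0-fold lower number from compound 1 to compound 3 (0.29 log units; within the scatter), a change at the same place that also involves 2-methoxyphenyl. Two further steps bear on the change: a 1.6-fold lower number from compound 2 to compound 3 (0.19 log units; within the scatter), and a 1.3-fold lower number from compound 1 to compound 2 (0.10 log units; within the scatter), which replaces fluoro with hydrogen on an aromatic carbon. For the measured compounds named here, all three lie within the scatter, and the series so far shows no clear response to changing this group. Three compounds are a thin basis, however, and none of them carries the 2,6-difluorophenyl group itself.

No step beyond the scatter is therefore expected in this assay, and any drift would more likely be towards a slightly higher number, given compound 1 at 16300 nM. The expected step is a 1.4-fold higher number from compound 3 to compound 4 (0.16 log units; within the scatter). The estimated value for compound 4 is 12000 nM, with an expected range of 6000 nM to 25000 nM.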

Compound 4, half-maximal inhibitory concentration: 15200 nM
Compound 4: the middle estimate sits 1.3-fold (0.10 log units) below what was measured; the measured number falls inside the stated range.
By their numbers in this assay, from the lowest: compounds 3, 2, 4 and 1 (each within the scatter of the next).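

In this assay, the 2,6-difluorophenyl group on the carbonyl carbon gives no step beyond the scatter against any of the three earlier groups (2-methoxyphenyl: a 1.8-fold higher number from compound 3 to compound 4 (0.26 log units; within the scatter); 2-chlorophenyl: a 1.2-fold higher number from compound 2 to compound 4 (0.07 log units; within the scatter); 2-chloro-6-fluorophenyl: a 1.1-fold lower number from compound 1 to compound 4 (0.03 log units; within the scatter)). The series now includes a group with 0 hydrogen-bond acceptors and no chlorine or oxygen, in place of 2-methoxyphenyl with 1 hydrogen-bond acceptor, and the four compounds still cannot be separated at this position. Nothing beyond these cell read-outs bears on why the values sit where they do.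

As far as these compounds go, all four groups are substituted phenyl rings, so it remains open whether a different kind of group on this carbonyl carbon, such as a carboxylic acid, an amine or a longer alkyl chain, would give a step beyond the scatter. It is also open whether any change at this position matters more than changes elsewhere on the shared core, as the compounds shown differ only here.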